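The source may report more compounds than this note shows. Statements on the series, on what has been measured and on what is new or still open speak of the compounds shown alone.

Working notes on the series, all read in a functional assay on MCF7 cells (Homo sapiens) for inhibition, read by sulforhodamine B assay, with a stated time of 48 h; on this read-out lower numbers stand for stronger inhibition of growth and higher numbers for weaker inhibition of growth. Compound 1 `Cc1nnc(-c2nn(-c3ccccc3)c(-c3ccccc3)c2C#N)c2cn(-c3ccccc3)nc12` gives 8460 nM. Compound 3 `N#Cc1c(-c2nnc(-c3ccccc3)c3nn(-c4ccccc4)cc23)nn(-c2ccccc2)c1-c1ccccc1` gives 9530 nM, level with compound 1 within the scatter. Compound 2 `N#Cc1c(-c2nnc(O)c3nn(-c4ccc(Cl)cc4)cc23)nn(-c2ccccc2)c1-c1ccccc1` reads > 100000 nM, which is a limit of the assay and not a number.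

The next structure is compound 4 `N#Cc1c(-c2nnc(-c3ccccc3)c3nn(-c4ccc(Cl)cc4)cc23)nn(-c2ccccc2)c1-c1ccccc1`, which has chloro in place of hydrogen on an aromatic carbon of compound 3, para to a large group, so that phenyl becomes 4-chlorophenyl: chloro in place of hydrogen on an aromatic carbon.

Within the data shown here, the only measured step is a 1.1-fold higher number from compound 1 to compound 3 (0.05 log units; within the scatter), phenyl in place of methyl on an aromatic carbon. It lies within the scatter, but it sits at a different place from the new chloro and gives only weak guidance. Among the measured compounds shown here, compound 2 also carries the 4-chlorophenyl group, but no measured pair isolates that group, and a limit gives no size for a step.

With so little evidence, no shift beyond the scatter is expected in this assay, and the uncertainty remains wide. The expected change is small, a 1.2-fold lower number from compound 3 to compound 4 (0.08 log units; within the scatter). The estimate rests on the value of compound 3, 9530 nM. The estimated value for compound 4 is 8000 nM, with an expected range of 2500 nM to 25000 nM.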

Compound 4, concentration for 50% growth inhibition: 43800 nM
Compound 4: the middle estimate sits 5.5-fold (0.74 log units) below what was measured; the measured number lies above the stated range.
By their numbers in this assay, from the lowest: compounds 1 and 3 (each within the scatter of the next); then compound 4. At a limit, above all of these: compound 2.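

In this assay, among these compounds, chloro in place of hydrogen on this six-membered aromatic ring of carbon only, para to a large group, is the first change among the compounds with a step beyond the scatter: a 4.6-fold higher number from compound 3 to compound 4 (0.66 log units; beyond the scatter), towards weaker inhibition of growth, whereas the earlier change of phenyl in place of methyl stayed within it, a 1.1-fold higher number from compound 1 to compound 3 (0.05 log units; within the scatter). With the 4-chlorophenyl group held fixed, phenyl in place of hydroxy also gives a step beyond the scatter, an at least 2.2-fold lower number from compound 2 to compound 4 (0.35 log units; beyond the scatter), towards stronger inhibition of growth. Compound 2 reads > 100000 nM, which is a limit of the assay and not a number, so this second step has a bound but no exact size: the limit of > 100000 nM in this assay, at which 1 of the 4 values shown sits.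

Only hydrogen and chloro are shown at this place, so it stays open whether the shift belongs to chloro alone or would also appear with a fluoro, a methoxy or an amine there. From the compounds shown here alone, it also stays open whether the same chloro step would hold with methyl in place of phenyl at the other site, the group carried by compound 1.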